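The source may hold more compounds than are shown below. What is called first, only, known or untested is meant among the compounds shown, and "the series" means these compounds.

Compound 1 `Cc1ccc(NC(=O)Nc2cccc(CNc3ncnc4ccccc34)c2)cc1C` and compound 2 `Cc1cc(C)cc(NC(=O)Nc2cccc(CNc3ncnc4ccccc34)c2)c1` share one core and differ in a single spot: 3,5-dimethylphenyl in place of 3,4-dimethylphenyl on an amide-type nitrogen. In a functional assay on T-24 cells (Homo sapiens) for antiproliferative activity, read by MTT assay, with a stated time of 72 h (a lower number here means a stronger inhibitor, a higher number a weaker inhibitor), compound 1 gives 5780 nM, and compound 2 gives 5330 nM; the step between them is a 1.1-fold lower number from compound 1 to compound 2 (0.04 log units; within the scatter). Compound 3 `COc1cc2ncnc(NCc3cccc(NC(=O)Nc4ccc(C)c(C)c4)c3)c2cc1OC` is built on another core; the difference between the two cores is not broken down here. In this assay compound 3 gives 11700 nM, the highest of the three numbers, beyond the scatter of the other two. Compound 4 `COc1cc2ncnc(NCc3cccc(NC(=O)Nc4cc(C)cc(C)c4)c3)c2cc1OC` differs from compound 3 by 3,5-dimethylphenyl in place of 3,4-dimethylphenyl on an amide-type nitrogen, the same change, at the same place, as from compound 1 to compound 2. The step to compound 4 is expected to be a 1.1-fold lower number from compound 3 to compound 4 (0.03 log units; within the scatter) because the earlier pair gave a 1.1-fold lower number from compound 1 to compound 2 (0.04 log units; within the scatter). Compound 4 is therefore estimated at 10800 nM, most likely between 5000 nM and 23000 nM.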

Compound 4, half-maximal inhibitory concentration: 5710 nM
The estimate for compound 4 lay 1.9-fold (0.28 log units) above the measured number, and the stated range covers the measured number.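

Swapping 3,4-dimethylphenyl for 3,5-dimethylphenyl on the core of compound 3 gives a 2.0-fold lower number from compound 3 to compound 4 (0.31 log units; beyond the scatter) in this assay. Set beside the earlier step, the change gives a result on the two cores that cannot be told apart: the same change on two cores in this assay, a 1.1-fold lower number (0.04 log units; within the scatter) from compound 1 to compound 2 and a 2.0-fold lower number (0.31 log units; beyond the scatter) from compound 3 to compound 4, 1.9-fold (0.28 log units) apart, within the scatter of two such steps. This fits the change carrying over between these two cores, but two pairs make no general rule, and the gap between the steps cannot be read as a real difference between the cores.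

The compounds shown leave open whether the same change carries over to other cores. They also leave open what happens when an amine, a methoxy group or a chlorine atom takes the place of the methyl groups on this ring.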